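Working notes: carbonyl on the chain of compound 3

The compounds below may be only part of what the source reports. "The series", "measured", "known", "first", "only" and "open" are said of these compounds alone.

Values so far in a functional assay on PC-3 cells (Homo sapiens) for inhibition, read by MTT assay, with a stated time of 48 h; on this read-out lower numbers stand for stronger inhibition and higher numbers for weaker inhibition:
compound 1 `COc1ccc(-n2c(SCc3ccccc3)nnc2-c2cc(OC)c(OC)c(OC)c2)cc1` gives 34100 nM
compound 2 `COc1ccc(-n2c(SCc3ccc(C)cc3)nnc2-c2cc(OC)c(OC)c(OC)c2)cc1` gives 56500 nM
compound 3 `COc1ccc(CSc2nnc(-c3cc(OC)c(OC)c(OC)c3)n2-c2ccc(OC)cc2)cc1` gives 40300 nM

Compound 3 at 40300 nM lies within the scatter of both compound 1 and compound 2, so the three values form a single group with no meaningful order.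

The next compound to be read in this assay is compound 4 `COc1ccc(C(=O)CSc2nnc(-c3cc(OC)c(OC)c(OC)c3)n2-c2ccc(OC)cc2)cc1`. The change is (4-methoxyphenyl)carbonyl in place of 4-methoxyphenyl on a saturated chain carbon bound to a sulfur.

For the measured compounds named here, three measured steps bear on this part of the series: a 1.7-fold higher number from compound 1 to compound 2 (0.22 log units; within the scatter), a 1.2-fold higher number from compound 1 to compound 3 (0.07 log units; within the scatter) and a 1.4-fold lower number from compound 2 to compound 3 (0.15 log units; within the scatter). All three stay within the scatter, but each only exchanges hydrogen, methyl or methoxy on an aromatic carbon. None of them adds a carbonyl to the chain, so they offer weak guidance and the range has to stay wide. No step beyond the scatter is expected, and no direction is favoured. The expected step is a 1.2-fold lower number from compound 3 to compound 4 (0.06 log units; within the scatter).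

For compound 4 the estimated value is 35000 nM, with an expected range from 11000 nM to 90000 nM.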

Compound 4, half-maximal inhibitory concentration: > 60000 nM
Compound 4: a limit, no number; the forecaster's own chance of this, stated with the estimate: 10%; middle value at least 1.7-fold (0.23 log units) away from the limit.
By their numbers in this assay, from the lowest: compounds 1, 3 and 2 (each within the scatter of the next). At a limit, above all of these: compound 4.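

In this assay compound 4 gives > 60000 nM, which is a limit of the assay and not a number. The steps read as floors only: an at least 1.4-fold higher number from compound 3 to compound 4 (0.17 log units; that floor lies within the scatter), an at least 1.0-fold higher number from compound 2 to compound 4 (0.02 log units; that floor lies within the scatter) and an at least 1.7-fold higher number from compound 1 to compound 4 (0.24 log units; that floor lies within the scatter); since each floor lies within the scatter, a loss beyond the scatter is not established against any of the three earlier compounds. For the compounds shown here, still, the earlier exchanges of hydrogen, methyl and methoxy on an aromatic carbon left compounds 1, 2 and 3 as one group with readable numbers, whereas (4-methoxyphenyl)carbonyl in place of 4-methoxyphenyl, on a saturated chain carbon bound to a sulfur, is the first change at the chain and gives no reading below the limit, so it shows no gain.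

As far as these compounds go, how far the true value of compound 4 lies past the limit stays open, as does whether the carbonyl itself or the longer link to the ring accounts for the result. Also open, from the compounds shown here alone, is whether an alcohol in place of the carbonyl, or a carboxylic acid on the chain bound to the sulfur, would give a readable number in this assay.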